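Three Limits and One Methoxy Removal in Cytotoxicity

This account rests on a few compounds, and the source may have more. Where it says the series, first, only, none or still open, it means among the compounds named here.

Measured so far:
compound 1 `O=C(c1ccncc1)N1N=C(c2cc3ccccc3o2)CC1c1ccccc1O`: > 195000 nM
compound 2 `COc1ccc(C2CC(c3cc4ccccc4o3)=NN2C(=O)c2ccncc2)c(O)c1`: > 190000 nM
compound 3 `COc1ccc(C2CC(c3cc4ccccc4o3)=NN2C(=O)c2ccncc2)cc1`: > 200000 nM

All three values come from an ADME assay on Vero cells (Chlorocebus sabaeus) for cytotoxicity, read by MTT assay, with a stated time of 72 h; a lower number here means a stronger inhibitor, a higher number a weaker inhibitor. For compound 1 the value > 195000 nM is a limit of the assay, not a number. For compound 2 the value > 190000 nM is likewise a limit. For compound 3 the value > 200000 nM is likewise a limit. The cores of compound 2 and compound 3 differ by hydrogen in place of hydroxy on an aromatic carbon. The change of interest, (hydrogen in place of methoxy on an aromatic carbon), gave a step that the two limits leave unreadable from compound 2 to compound 1. The same kind of change leads to compound 4 `O=C(c1ccncc1)N1N=C(c2cc3ccccc3o2)CC1c1ccccc1` as hydrogen in place of methoxy on an aromatic carbon; the place in compound 2 is also meta to a hydroxy group, the place in compound 3 is not. The step from compound 3 to compound 4 is expected to be a step that the limit leaves unreadable from compound 3 to compound 4, an expectation resting on (the limit of > 190000 nM in this assay, at which 1 of the 3 values shown sits), the limit of > 195000 nM in this assay, at which 1 of the 3 values shown sits, and (the limit of > 200000 nM in this assay, at which 1 of the 3 values shown sits). Compound 4 is therefore expected to give 250000 nM, most likely again a limit.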

Compound 4, half-maximal inhibitory concentration: > 209000 nM
Compound 4: a limit, no number; the forecaster's own chance of this, stated with the estimate: 85%; the middle value does not contradict the limit.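

In this assay compound 4 gives > 209000 nM, which is again a limit and not a number. Within the data shown here, no step between compound 4 and compound 1, compound 2 or compound 3 can be read. The compounds shown leave open the concentration at which any of them would actually reach half-maximal inhibition.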